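Chalcone anilides: chloro to methoxy on the styryl ring

The source may hold more compounds than are shown below. What is called first, only, known or untested is meant among the compounds shown, and "the series" means these compounds.

Compound 1 `CC(O[N+](=O)[O-])C(=O)Nc1ccc(C(=O)/C=C/c2ccc(Cl)cc2)cc1` gives 62% in a functional assay on the whole organism (strain albino) for inhibition, with Rattus norvegicus as the target, read by paw edema, with stated times of 30 min and 3 h, at a dose of 100 mg/kg by the oral route; on this read-out lower numbers stand for less inhibition and higher numbers for more inhibition at the one dose given (going by the name of the read-out). Compound 2 `COc1ccc(/C=C/C(=O)c2ccc(NC(=O)C(C)O[N+](=O)[O-])cc2)cc1` carries the change methoxy in place of chloro on an aromatic carbon and in this assay compound 2 gives 50%, so the step runs a number 12 percentage points lower from compound 1 to compound 2 (beyond the scatter). Compound 3 `CC(=O)c1ccc(OCC(=O)Nc2ccc(C(=O)/C=C/c3ccc(Cl)cc3)cc2)cc1` has a different amide side on the shared anilide; the difference between the two cores is not broken down here. In this assay compound 3 gives 61%, which sits within the scatter of compound 1 and beyond it against compound 2.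

Compound 4 `COc1ccc(/C=C/C(=O)c2ccc(NC(=O)COc3ccc(C(C)=O)cc3)cc2)cc1` is not yet measured. It differs from compound 3 by methoxy in place of chloro on an aromatic carbon, the same change as from compound 1 to compound 2, at the same kind of place. For the measured compounds named here, for compound 4 in this assay a step of a number 12 percentage points lower from compound 3 to compound 4 (beyond the scatter) is expected, set beside the earlier step because a number 12 percentage points lower from compound 1 to compound 2 (beyond the scatter) is the only measured instance of this change. The estimate rests on a single pair, so its span is kept wide. Compound 4 is expected to reach about 49%, between 39% and 60%.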

Compound 4, a percentage reported as inhibition, in the whole organism at one dose (the size of the read-out at that dose, not a potency): 42%
Beside the measured number, compound 4's estimate is 7 percentage points above it, within the range that was stated.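

In this assay the change from 4-chlorophenyl to 4-methoxyphenyl on the core of compound 3 reads a number 19 percentage points lower from compound 3 to compound 4 (beyond the scatter). Set beside the earlier step, the change carries across the two cores in the same direction, and the two sizes cannot be told apart: the same change on two cores in this assay, a number 12 percentage points lower (beyond the scatter) from compound 1 to compound 2 and a number 19 percentage points lower (beyond the scatter) from compound 3 to compound 4, 7 percentage points apart, within the scatter of two such steps. This rests on two pairs, one read-out and a single dose, so it gives no rule for cores outside these four compounds, no potency, and no reason for the lower numbers.

The compounds shown hold only chloro and methoxy at this place on the aromatic ring, leaving open how a fluoro, a hydroxy or an amine would read there. As far as these compounds go, on the amide side only the groups of compound 1 and compound 3 appear, so it remains open whether the step keeps its direction and size with a carboxylic acid or a longer chain on that side.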